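The compounds below may be only part of what the source reports. "The series", "measured", "known", "first", "only" and "open" are said of these compounds alone.

Compound 3 `c1ccc(Oc2ccc3c(NCCCNCc4ccco4)ccnc3c2)cc1` gives 9.28 in a physicochemical assay for acid dissociation, the lowest of the three numbers recorded, though every gap to its neighbours lies within the scatter: compound 1 `CC(C)Cc1ccc2c(NCCCNCc3ccco3)ccnc2c1` gives 9.47 and compound 2 `CC(C)CCc1ccc2c(NCCCNCc3ccco3)ccnc2c1` gives 9.47, so that a number 0.19 log units lower from compound 1 to compound 3 (within the scatter), a number 0.19 log units lower from compound 2 to compound 3 (within the scatter) and no change at the digits printed from compound 1 to compound 2 (within the scatter). Compound 4 `COc1ccc(Oc2ccc3c(NCCCNCc4ccco4)ccnc3c2)cc1` differs from compound 3 by methoxy in place of hydrogen on an aromatic carbon. Within the data shown here, no measured step touched this position; the three known steps swapped the whole substituent on the aromatic carbon of the shared core, and none moved the read-out beyond the scatter. On that basis the expected step is a number 0.02 log units higher from compound 3 to compound 4 (within the scatter), nothing beyond the scatter. Compound 4 is therefore estimated at 9.3 in this assay, between 9 and 9.6.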

Compound 4, acid dissociation constant: 9.28
Beside the measured number, compound 4's estimate is 0.02 log units above it; measured number inside the range.
By their numbers in this assay, from the lowest: compounds 3, 4, 1 and 2 (each within the scatter of the next).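

In this assay, methoxy in place of hydrogen on the outer ring, para to a large group, gives no change at the digits printed from compound 3 to compound 4 (within the scatter) as the first change made within the phenoxy group rather than to the whole substituent. Whole-group swaps to 4-methoxyphenoxy stay equally small: replacing isobutyl gives a number 0.19 log units lower from compound 1 to compound 4 (within the scatter) and replacing isopentyl gives a number 0.19 log units lower from compound 2 to compound 4 (within the scatter) as well. Nothing available explains these numbers. As far as these compounds go, whether an amine or a carboxylic acid at this same place would move the number beyond the scatter remains open.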